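Swapping the Benzyl Substituent in a Chalcone Amine

The compounds below may be only part of what the source reports. "The series", "measured", "known", "first", "only" and "open" are said of these compounds alone.

Of the compounds shown here, three sharing one core have been tested in an assay on isolated protein for inhibition of Amine oxidase [flavin-containing] B (Homo sapiens); on this read-out higher numbers stand for weaker inhibition and lower numbers for stronger inhibition. Compound 1, `COc1ccc(C(=O)/C=C/c2ccc(N(C)C)cc2)c(O)c1`, the bare core, gives 210 nM. Compound 2, `CCN(CCCCCCOc1ccc(C(=O)/C=C/c2ccc(N(C)C)cc2)c(O)c1)Cc1ccccc1OC`, carries a long chain ending in an amine that bears a 2-methoxybenzyl group, and in this assay compound 2 gives 700 nM. Compound 3, `CCN(CCCCOc1ccc(C(=O)/C=C/c2ccc(N(C)C)cc2)c(O)c1)Cc1ccccc1`, with a shorter chain and a plain benzyl group, gives 8900 nM. Among these three numbers compound 2 stands second highest: compound 1 lies lower and compound 3 lies higher, and both gaps exceed the usual scatter.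

Compound 4, `CCN(CCCCCCOc1ccc(C(=O)/C=C/c2ccc(N(C)C)cc2)c(O)c1)Cc1ccc(N(C)C)cc1`, differs from compound 2 in one place: 4-(dimethylamino)phenyl in place of 2-methoxyphenyl on a saturated chain carbon bound to an amine nitrogen. Among the measured compounds shown here, no measured pair shows this particular change, so its effect can only be guessed. Since compound 2 and compound 3 differ in both chain length and benzyl substituent, neither isolates the substituent's role. A small step is expected, a 1.3-fold higher number from compound 2 to compound 4 (0.11 log units; within the scatter), not clearly beyond the scatter in either direction. Compound 4 is therefore estimated at 900 nM, within 300 nM to 3000 nM.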

Compound 4, half-maximal inhibitory concentration: 2300 nM
Estimate against measurement, compound 4: 2.6-fold (0.41 log units) below; low and high end bracket the measured number.
By their numbers in this assay, from the lowest: compound 1; then compound 2; then compound 4; then compound 3.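

Among the compounds shown here, with the chain held the same, this comparison isolates the benzyl substituent for the first time: 4-(dimethylamino)phenyl in place of 2-methoxyphenyl gives a 3.3-fold higher number from compound 2 to compound 4 (0.52 log units; beyond the scatter) in this assay, which means weaker inhibition. This position therefore responds to the change on its own, without any change in chain length. The two groups have the same counts of hydrogen-bond donors and acceptors and the same net charge, so those counts do not distinguish them, and nothing measured here accounts for the step.

This swap alters both the substituent and its place on the ring, so the effects of the two cannot yet be separated; a methoxy group and a dimethylamino group exchanged between those two ring places would address that. Also open, as far as these compounds go, is how a plain benzyl or a fluorobenzyl group would compare on this same chain.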